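Methyl for methylamino on a nucleoside core with no reference

This account rests on a few compounds, and the source may have more. Where it says the series, first, only, none or still open, it means among the compounds named here.

Three compounds have been measured in a functional assay on HL-60 cells (Homo sapiens) for antiproliferative activity, read by XTT assay, with a stated time of 72 h; a lower number here means a stronger inhibitor, a higher number a weaker inhibitor:

- compound 1 `CNc1ncnc2c1c(-c1ccsc1)cn2[C@@H]1O[C@H](CO)[C@@H](O)[C@H]1O` gives > 20000 nM, a limit of the assay.
- compound 2 `CNc1ncnc2c1c(-c1cccs1)cn2[C@@H]1O[C@H](CO)[C@@H](O)[C@H]1O` gives > 20000 nM, a limit of the assay.
- compound 3 `CNc1ncnc2c1c(-c1ccoc1)cn2[C@@H]1O[C@H](CO)[C@@H](O)[C@H]1O` gives > 15000 nM, a limit of the assay.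

Compound 3 therefore stands only at a limit, as do the other two, one of them at the limit of > 15000 nM in this assay, at which 1 of the 3 values shown sits, and two at the limit of > 20000 nM in this assay, at which 2 of the 3 values shown sit. The steps among the measured compounds, a step that the two limits leave unreadable from compound 1 to compound 2, a step that the two limits leave unreadable from compound 1 to compound 3 and a step that the two limits leave unreadable from compound 2 to compound 3, concern the five-membered ring on the core and cannot be read from these limits. Among the compounds with values here, compound 4 `Cc1ncnc2c1c(-c1ccoc1)cn2[C@@H]1O[C@H](CO)[C@@H](O)[C@H]1O` differs from compound 3 by methyl in place of methylamino on an aromatic carbon, a change at a different place on the core, on which none of the measured steps bears. With nothing in this assay to point either way, compound 4 is expected to remain at or near a limit, with an estimated step that the limit leaves unreadable from compound 3 to compound 4. Compound 4 is estimated at 20000 nM, in a range from 5000 nM to 60000 nM.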

Compound 4, half-maximal inhibitory concentration: > 15000 nM
Compound 4: only a limit was reported; the forecaster's own chance of this, stated with the estimate: 80%; the middle value is on the limit's open side.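

No new step can be read between compound 3 and compound 4, because both stand at a limit in this assay: the limit of > 15000 nM in this assay, at which 2 of the 4 values shown sit.

The compounds shown leave open whether methyl in place of methylamino, or any change of the five-membered ring, alters the activity at all.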